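Toward compound 4: swapping the aryl group on the piperazine

The source may hold more compounds than are shown below. What is called first, only, known or untested is meant among the compounds shown, and "the series" means these compounds.

Compound 1 `NC(=O)[C@@H]1CCCN1C(=O)CCCCCN1CCN(c2cccc(Cl)c2Cl)CC1`: 179 nM
Compound 2 `CSc1ccccc1N1CCN(CCCCC(=O)N2Cc3ccccc3C[C@H]2C(N)=O)CC1`: 51 nM
Compound 3 `COc1ccccc1N1CCN(CCCCC(=O)N2Cc3ccccc3C[C@H]2C(N)=O)CC1`: 551 nM

Of the compounds shown here, three have been measured in an assay on HEK293 cells for displacement of a labelled ligand from 5-hydroxytryptamine receptor 7 (Homo sapiens), with a stated time of 1 h; on this read-out higher numbers stand for weaker inhibition and lower numbers for stronger inhibition. Compound 3 stands at the high end of these numbers, so it is the weakest inhibitor of the three: compound 1 sits at a lower number, and compound 2 at a lower number still. Among the measured compounds shown here, the one step that has been characterised, an 11-fold higher number from compound 2 to compound 3 (1.03 log units; beyond the scatter), concerns the group on an aromatic carbon and is large.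

Compound 4 `NC(=O)[C@@H]1Cc2ccccc2CN1C(=O)CCCCN1CCN(c2ccc(Cl)cc2)CC1` arises from compound 3 by a change in a different place: 4-chlorophenyl in place of 2-methoxyphenyl on an amine nitrogen in a ring. For the measured compounds named here, no measured pair isolates this change. The step between compound 2 and compound 3 touches the same aryl ring but alters a different substituent, and compound 1 carries a different core along with its own aryl group, so its number cannot be set against compound 3 directly. Going by the values given here, what is known is only that the aryl group on the piperazine can shift the number in this assay strongly, in either direction. The expectation for compound 4 is therefore wide and leans toward a somewhat lower number than compound 3, estimated as a 1.8-fold lower number from compound 3 to compound 4 (0.26 log units; within the scatter), giving an expected value of 300 nM with a range from 80 nM to 1200 nM.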

Compound 4, inhibition constant: 223 nM
Beside the measured number, compound 4's estimate is 1.3-fold (0.13 log units) above it; low and high end bracket the measured number.
By their numbers in this assay, from the lowest: compound 2; then compounds 1 and 4 (each within the scatter of the next); then compound 3.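

Across the aryl groups on this amine nitrogen, 4-chlorophenyl falls in the middle in this assay. It gives a 2.5-fold lower number from compound 3 to compound 4 (0.39 log units; beyond the scatter) and also a 4.4-fold higher number from compound 2 to compound 4 (0.64 log units; beyond the scatter), and both steps lie beyond the scatter, so the three aryl groups on the shared core give three separate levels. The earlier pair showed only that changing one substituent on the ring could move the number, whereas compound 4 shows that a ring carrying chlorine, with neither oxygen nor sulfur in its substituent, is better than 2-methoxyphenyl in this assay but falls short of 2-(methylsulfanyl)phenyl. No measurement shown here explains these differences.

The swap from 2-methoxyphenyl to 4-chlorophenyl changes both the substituent and where it stands on the ring, and the compounds shown cannot separate those two changes. A plain phenyl group on the same nitrogen, carrying neither chlorine nor methoxy, would give a reference for judging what each substituent adds or takes away.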